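Swapping Phenyl for Thiophen-2-yl in a Small Series

A few compounds are considered here, and "the series" means these few. Any claim that something is new, unique, unknown or untested is made for them only; others in the source may bear on it.

Of the compounds shown here, three have been tested so far in a functional assay on HeLa cells (Homo sapiens) for cytotoxicity, read by ELISA, with a stated time of 2 days; on this read-out lower numbers stand for stronger inhibition and higher numbers for weaker inhibition. In it, compound 1 `Oc1cccc(-c2cc(-c3ccccc3)cc(-c3ccco3)n2)c1` gives 9430 nM, compound 2 `Oc1ccc(-c2cc(-c3ccccc3)cc(-c3ccsc3)n2)cc1` gives 17300 nM and compound 3 `Oc1cccc(-c2cc(-c3ccccc3)nc(-c3ccccc3)c2)c1` gives 15100 nM. Compound 3 stands in the middle of these three numbers, and its gaps to compound 1 and compound 2 both lie within the scatter of repeated measurements.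

Compound 4 `Oc1cccc(-c2cc(-c3ccccc3)nc(-c3cccs3)c2)c1` has thiophen-2-yl in place of a phenyl on an aromatic carbon next to the ring nitrogen of compound 3: thiophen-2-yl in place of phenyl on an aromatic carbon. Among the compounds with values here, no measured pair isolates this swap, so there is no direct guide to its size. Compound 1 and compound 2 each carry a five-membered aromatic ring with 1 hetero atom, and neither differs from compound 3 beyond the scatter, which gives only indirect support for expecting a small change. The estimated change is a 1.3-fold lower number from compound 3 to compound 4 (0.10 log units; within the scatter), a slight move toward a lower number that stays within the scatter. For compound 4 the expected value is 12000 nM, with an estimated range of 5500 nM to 26000 nM.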

Compound 4, half-maximal inhibitory concentration: 15300 nM
For compound 4 the middle estimate is 1.3-fold (0.11 log units) below the measured one; the measured number falls inside the stated range.
By their numbers in this assay, from the lowest: compounds 1, 3, 4 and 2 (each within the scatter of the next).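

In this assay, putting thiophen-2-yl in place of phenyl on an aromatic carbon next to the ring nitrogen gives a 1.0-fold higher number from compound 3 to compound 4 (0.01 log units; within the scatter), the only direct reading of this change among the compounds shown. At this position, then, a five-membered aromatic ring containing sulfur can replace the six-membered carbon ring with no difference that this read-out can separate from the scatter. Nothing available explains why the two groups read alike here.

On these data alone, compound 3 and compound 4 both carry an aromatic ring at this position, so it remains open whether an amine, a carboxylic acid or a longer alkyl chain there would shift the number beyond the scatter. Also open, as far as these compounds go, is whether the same swap would read alike on the remaining phenyl group of compound 4.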